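Swapping a fluoro for a (dimethylamino)methyl group

A few compounds are considered here, and "the series" means these few. Any claim that something is new, unique, unknown or untested is made for them only; others in the source may bear on it.

Measured so far:
compound 1 `CCN1CCN(CCCn2cnc3c(N4CCN(C(=O)C5CCCC5)CC4)nc(NCc4ccc(N(CC)CC)cc4)nc32)CC1`: 8800 nM
compound 2 `CCN1CCN(c2nc(NCc3ccc(F)cc3)nc3c2ncn3CCCN2CCCC2)CC1`: 40 nM

In an assay on HEK293 cells for antagonist activity at Toll-like receptor 9 (Homo sapiens), read by spectrophotometry (on this read-out higher numbers stand for weaker inhibition and lower numbers for stronger inhibition), compound 2 gives the lower of the two numbers, and compound 1 gives a number far higher, well beyond the scatter. Compound 3 `CCN1CCN(c2nc(NCc3ccc(CN(C)C)cc3)nc3c2ncn3CCCN2CCCC2)CC1` is not yet measured. It differs from compound 2 by (dimethylamino)methyl in place of fluoro on an aromatic carbon. Among the compounds with values here, no single-change step between measured compounds is known here. A small shift toward a higher number is expected, a 2.0-fold higher number from compound 2 to compound 3 (0.30 log units; within the scatter), close to the scatter. Compound 3 is therefore estimated at 80 nM in this assay, with a likely range from 20 nM to 400 nM.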

Compound 3, half-maximal inhibitory concentration in the Toll-like receptor 9 assay: 90 nM
Estimate against measurement, compound 3: 1.1-fold (0.05 log units) below, and the stated range covers the measured number.
By their numbers in the Toll-like receptor 9 assay, from the lowest: compound 2; then compound 3; then compound 1.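

Swapping fluoro for (dimethylamino)methyl at this aromatic carbon costs only modestly in the Toll-like receptor 9 assay, where compound 2 gives 40 nM and compound 3 gives 90 nM, with a 2.3-fold higher number from compound 2 to compound 3 (0.35 log units; beyond the scatter), so this position accepts a group with a nitrogen and more heavy atoms while inhibition stays measurable. In a physicochemical assay for solubility, with a stated time of 18 h, at pH 7.4 (on this read-out lower numbers stand for lower solubility and higher numbers for higher solubility), compound 2 gives 218 ug/mL and compound 3 gives 136 ug/mL, and the same swap gives a 1.6-fold lower number from compound 2 to compound 3 (0.20 log units; within the scatter), which lies within the scatter, so no solubility difference can be claimed. Nothing shown explains the shift in inhibition.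

On these data alone, how a carboxylic acid or a longer chain ending in an amine would behave at this position remains open. So does whether this small cost would hold with other groups elsewhere on the shared core.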